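Enlarging the ester of compound 1

The source may hold more compounds than are shown below. What is called first, only, known or untested is meant among the compounds shown, and "the series" means these compounds.

Measured in a functional assay on MV4-11 cells (Homo sapiens) for antiproliferative activity, read by luminescence, with a stated time of 72 h; a lower number here means a stronger inhibitor, a higher number a weaker inhibitor:
Compound 1 `CCN(CC)C/C=C/C(=O)NC/C=C/c1cc(OC)cc(O)c1C(=O)OC(C)C`: > 10000 nM (a limit)
Compound 2 `CCN(CC)C/C=C/C(=O)NC/C=C/c1cc(OCCc2ccc(F)cc2)cc(O)c1C(=O)OC(C)C`: 4040 nM
Compound 3 `C/C=C/C(=O)NC/C=C/c1cc(OC)cc(O)c1C(=O)OC(C)C`: > 10000 nM (a limit)

In this assay compound 1 gives only a limit, > 10000 nM. That is the limit of > 10000 nM in this assay, at which 2 of the 3 values shown sit.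

Compound 4 `CCN(CC)C/C=C/C(=O)NC/C=C/c1cc(OC)cc(O)c1C(=O)O[C@@H](C)C(C)C` carries 1,2-dimethylpropyl in place of isopropyl on an oxygen next to a carbonyl group.

Within the data shown here, no measured step changes this group. The nearest guide lies elsewhere on the molecule: an at least 2.4-fold lower number from compound 1 to compound 2 (0.39 log units; beyond the scatter), with 4-fluorobenzyl in place of hydrogen. The other step, a step that the two limits leave unreadable from compound 1 to compound 3, gives no size.

The expected step is small and towards a lower number: an at least 1.2-fold lower number from compound 1 to compound 4 (0.09 log units; that floor lies within the scatter). Another limit is quite possible. For compound 4 the estimated value is 8000 nM, with an expected range of 2500 nM to 20000 nM.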

Compound 4, half-maximal inhibitory concentration: > 10000 nM
Compound 4: no number, only a limit; the forecaster's own chance of this, stated with the estimate: 55%; middle value at least 1.2-fold (0.09 log units) away from the limit.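

In this assay compound 4 gives > 10000 nM, a limit, and compound 1 also gives only a limit, so the step between them cannot be read: the limit of > 10000 nM in this assay, at which 3 of the 4 values shown sit.

The compounds shown leave open whether 1,2-dimethylpropyl in place of isopropyl changes the number at all.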